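The source may hold more compounds than are shown below. What is called first, only, known or untested is meant among the compounds shown, and "the series" means these compounds.

Compound 1 `Cn1c(=O)c(S(=O)(=O)c2ccc(C(=O)O)cc2)cc2cnc(Nc3ccc4[nH]ccc4c3)nc21` is tested in a functional assay on DU-145 cells (Homo sapiens) for inhibition, read by trypan blue exclusion, with a stated time of 72 h (a higher number here means a weaker inhibitor, a lower number a stronger inhibitor), where compound 1 gives 10000 nM. Compound 3 `O=c1c(S(=O)(=O)c2ccc(F)cc2F)cc2cnc(Nc3ccc4[nH]ccc4c3)nc2n1C1CCCCC1` gives 10000 nM in this assay, level with compound 1 at the digits shown, and these two stand together as the lowest of the three numbers. Compound 2 `COc1ccc(Nc2ncc3cc(S(=O)(=O)c4ccc(C)cc4)c(=O)n(C)c3n2)cc1` gives 100000 nM in this assay, a number that lies beyond the scatter above compound 1. Compound 4 `Cn1c(=O)c(S(=O)(=O)c2ccc(N)cc2F)cc2cnc(Nc3ccc4[nH]ccc4c3)nc21` is not yet measured in this assay. It differs from compound 1 in one place: 4-amino-2-fluorophenyl in place of 4-carboxyphenyl on a sulfonyl sulfur. Among the measured compounds shown here, no measured pair shows this change, so there is nothing to fix its size. For compound 4 in this assay a step of a 1.3-fold lower number from compound 1 to compound 4 (0.10 log units; within the scatter) is expected, that is, no change beyond the scatter. Compound 4 is estimated at 8000 nM, with a range from 2500 nM to 30000 nM.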

Compound 4, half-maximal inhibitory concentration: 8000 nM
Beside the measured number, compound 4's estimate shows no gap at the digits printed; the range from low to high includes it.
By their numbers in this assay, from the lowest: compounds 4, 1 and 3 (each within the scatter of the next); then compound 2.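

In this assay, among the compounds shown here, 4-amino-2-fluorophenyl in place of 4-carboxyphenyl on a sulfonyl sulfur gives a 1.3-fold lower number from compound 1 to compound 4 (0.10 log units; within the scatter) and is the only step read at this place. On the core of compound 1, the carboxylic acid can thus give way to an amine and a fluorine without a shift beyond the scatter. No supporting measurement is available to explain this result. As far as these compounds go, it remains open whether the amine alone or the fluorine alone would hold the number there. A methoxy group or a nitrile on that phenyl might also behave differently.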